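Replacing the 1,3-benzoxazol-2-yl group of compound 3

This account rests on a few compounds, and the source may have more. Where it says the series, first, only, none or still open, it means among the compounds named here.

In a functional assay on K562 cells (Homo sapiens) for antiproliferative activity, read by MTT assay, with a stated time of 48 h (on this read-out lower numbers stand for stronger inhibition and higher numbers for weaker inhibition), compound 3 (`CN(C)CCCCn1c(N)c(-c2nc3ccccc3o2)c2nc(C#N)c(C#N)nc21`) gives 1380 nM, the lowest number in the set. Compound 1 (`CN(C)CCCn1c(N)c(-c2nc3ccccc3o2)c2nc(C#N)c(C#N)nc21`) gives 5900 nM. Compound 2 (`N#Cc1nc2c(-c3nc4ccccc4o3)c(N)n(CCCN3CCCCC3)c2nc1C#N`) reaches only a limit of the assay, > 50000 nM. Compound 4 (`CN(C)CCCCn1c(N)c(-c2nc3ccccc3n2C)c2nc(C#N)c(C#N)nc21`) differs from compound 3 in one place: 1-methyl-1H-benzimidazol-2-yl in place of 1,3-benzoxazol-2-yl on an aromatic carbon. Here 1-methyl-1H-benzimidazol-2-yl stands in place of 1,3-benzoxazol-2-yl on an aromatic carbon. The measured steps all lie in the side chain: a 4.3-fold lower number from compound 1 to compound 3 (0.63 log units; beyond the scatter), an at least 8.4-fold higher number from compound 1 to compound 2 (0.92 log units; beyond the scatter) and an at least 36-fold lower number from compound 2 to compound 3 (1.55 log units; beyond the scatter). None of them touches this aromatic carbon, so their modest to large sizes do not carry over, and no step beyond the scatter is expected in this assay. The expected step is a 1.4-fold higher number from compound 3 to compound 4 (0.16 log units; within the scatter). For compound 4 the estimated value is 2000 nM, with an expected range from 400 nM to 10000 nM.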

Compound 4, half-maximal inhibitory concentration: 1450 nM
For compound 4 the middle estimate is 1.4-fold (0.14 log units) above the measured one, within the range that was stated.
By their numbers in this assay, from the lowest: compounds 3 and 4 (each within the scatter of the next); then compound 1. At a limit, above all of these: compound 2.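

Placing 1-methyl-1H-benzimidazol-2-yl on this aromatic carbon in place of 1,3-benzoxazol-2-yl gives a 1.1-fold higher number from compound 3 to compound 4 (0.02 log units; within the scatter) in this assay, the only step shown at this position. With the 4-(dimethylamino)butyl group in place, this position therefore takes either group without a change beyond the scatter. Nothing measured here bears on why the two groups match.

Going by these compounds, whether they also match on the side chain of compound 1 remains open. Also open, on these data alone, is how this position responds to a plain phenyl group or to 1H-benzimidazol-2-yl without the methyl.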